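Cytotoxicity of sec-butyl and butyl thioether pyrimidinones

A few compounds are considered here, and "the series" means these few. Any claim that something is new, unique, unknown or untested is made for them only; others in the source may bear on it.

Compound 1 `CCC(C)Sc1nc(C(C)c2c(F)cccc2Cl)cc(=O)[nH]1` and compound 2 `CCCCSc1nc(C(C)c2c(F)cccc2Cl)cc(=O)[nH]1` share a core and differ by butyl in place of sec-butyl on a sulfur. In an ADME assay on MT4 cells (Homo sapiens) for activation, read by MTT assay (on this read-out higher numbers stand for lower toxicity in this test and lower numbers for higher toxicity in this test), compound 1 gives > 73000 nM, which is a limit of the assay and not a number. In this assay compound 2 likewise gives > 73000 nM, again a limit. The step that the two limits leave unreadable from compound 1 to compound 2 therefore cannot be read, as the limit of > 73000 nM in this assay, at which 2 of the 3 values shown sit, shows.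

Compound 3 `CCC(C)Sc1nc(C(CC)c2c(F)cccc2F)c(C)c(=O)[nH]1` carries a different core; the difference between the two cores is not broken down here. In this assay compound 3 gives > 3000 nM, a limit, as the limit of > 3000 nM in this assay, at which 1 of the 3 values shown sits, records.

Compound 4 `CCCCSc1nc(C(CC)c2c(F)cccc2F)c(C)c(=O)[nH]1` differs from compound 3 by butyl in place of sec-butyl on a sulfur, the same change that separates compound 1 from compound 2. Compound 4 is expected to stay at or beyond the limit in this assay, because a step that the two limits leave unreadable from compound 1 to compound 2 left both of those compounds at the limit and compound 3 is itself only known as > 3000 nM. The expected step is a step that the limit leaves unreadable from compound 3 to compound 4. Compound 4 is thus estimated at 50000 nM, within 8000 nM to 250000 nM.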

Compound 4, half-maximal cytotoxic concentration: > 3000 nM
Compound 4: a limit, no number; the forecaster's own chance of this, stated with the estimate: 85%; the middle value is on the limit's open side.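

In this assay compound 4 gives > 3000 nM, a limit and not a number. Compound 3 and compound 4 are both known only as limits, and the step between them cannot be read. The compounds shown leave open whether butyl in place of sec-butyl on a sulfur shifts the half-maximal cytotoxic concentration at all, on either core.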